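The source may report more compounds than this note shows. Statements on the series, on what has been measured and on what is new or still open speak of the compounds shown alone.

Measured compounds:
Compound 1 `COc1ccc(/C=C/C(=O)c2ccc(NC(=O)CBr)cc2)cc1` gives 41% in a functional assay on the whole organism (strain albino) for inhibition, with Rattus norvegicus as the target, read by paw edema, with stated times of 30 min and 4 h, at a dose of 100 mg/kg by the oral route; on this read-out lower numbers stand for less inhibition and higher numbers for more inhibition at the one dose given (going by the name of the read-out).
Compound 2 `CC(O[N+](=O)[O-])C(=O)Nc1ccc(C(=O)/C=C/c2ccc(Cl)cc2)cc1` gives 61% in this assay.

Compound 2 stands highest of the two numbers, with compound 1 lying lower by a gap beyond the usual scatter. Compound 3, `COc1ccc(/C=C/C(=O)c2ccc(NC(=O)C(C)O[N+](=O)[O-])cc2)cc1`, is not yet measured. It differs from compound 2 in one place: methoxy in place of chloro on an aromatic carbon. No measured pair shows this change on its own, so its size cannot be read from the numbers shown. In this assay compound 3 is expected to give 52%, within a range from 35% to 68%. That estimate means a step of a number 9 percentage points lower from compound 2 to compound 3 (within the scatter), expected to be small, downward if anywhere, and near the edge of the scatter.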

Compound 3, a percentage reported as inhibition, in the whole organism at one dose (the size of the read-out at that dose, not a potency): 43%
Compound 3: middle estimate off by 9 percentage points, on the high side; low and high end bracket the measured number.
By their numbers in this assay, from the lowest: compounds 1 and 3 (each within the scatter of the next); then compound 2.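

In this assay, the change from 4-chlorophenyl to 4-methoxyphenyl now has a size of its own: a number 18 percentage points lower from compound 2 to compound 3 (beyond the scatter), so the group at this place on the aromatic ring can move the read-out. With the methoxy kept, 1-(nitrooxy)ethyl in place of bromomethyl gives a number 2 percentage points higher from compound 1 to compound 3 (within the scatter), so this swap shows no clear effect here. Nothing measured here explains either step.

Going by these compounds, whether an amine or a hydroxyl at this place would fall nearer to chloro or to methoxy remains open. So does whether the bromomethyl swap would also show no clear effect with chloro on the ring.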